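This account rests on a few compounds, and the source may have more. Where it says the series, first, only, none or still open, it means among the compounds named here.

Compound 1 `COc1ccc(-c2cc(/C=C/C(=O)c3ccc(N)cc3)[nH]n2)cc1`, compound 2 `COc1ccc(-c2cc(/C=C/C(=O)c3ccc(N)cc3)[nH]n2)cc1OC` and compound 3 `COc1cc(C(=O)/C=C/c2cc(-c3cc(OC)c(OC)c(OC)c3)n[nH]2)cc(OC)c1OC` share a core and were all tested in a functional assay on SK-OV-3 cells (Homo sapiens) for cytotoxicity, read by sulforhodamine B assay, with a stated time of 48 h, tested at 100 uM; a lower number here means a stronger effect, a higher number a weaker effect of the compound at the concentration tested. In this assay compound 1 gives -68%, compound 2 gives -99% and compound 3 gives -100%. Compound 2 and compound 1 differ in one place, (hydrogen in place of methoxy on an aromatic carbon), and that change produced a step of a number 31 percentage points higher from compound 2 to compound 1 (beyond the scatter). The values of compound 2 and compound 3 lie within the usual scatter of each other, and the difference between their two cores is not broken down here.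

Compound 4 `COc1ccc(-c2cc(/C=C/C(=O)c3cc(OC)c(OC)c(OC)c3)[nH]n2)cc1OC` has not yet been measured in this assay. It differs from compound 3 by hydrogen in place of methoxy on an aromatic carbon. Among the measured compounds shown here, this is the same kind of change as the one from compound 2 to compound 1, though not the same: in both cases the carbon is ortho to a methoxy group and meta to a large group, but in compound 3 it is also meta to a methoxy group. The earlier step, a number 31 percentage points higher from compound 2 to compound 1 (beyond the scatter), shows a clear weakening. For compound 4 a weakening of the same direction but of smaller size is expected, an estimated step of a number 8 percentage points higher from compound 3 to compound 4 (within the scatter), because compound 2 gives -99% while carrying the same two methoxy groups on that ring as compound 4. Compound 4 is therefore expected to give about -92% in this assay, most likely between -100% and -70%.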

Compound 4, a percentage reported as activity, at one concentration (the size of the read-out at that concentration, not a potency): -95%
Beside the measured number, compound 4's estimate is 3 percentage points above it, and the stated range covers the measured number.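

In this assay, hydrogen in place of methoxy on the core of compound 3 gave a step of a number 5 percentage points higher from compound 3 to compound 4 (within the scatter), so on this core the loss of that methoxy group cannot be told apart from the usual variation between repeats. Set beside the earlier step, the same change did not carry its size over from one core to the other: the same change on two cores in this assay, a number 31 percentage points higher (beyond the scatter) from compound 2 to compound 1 and a number 5 percentage points higher (within the scatter) from compound 3 to compound 4, 26 percentage points apart, beyond the scatter of two such steps. Among the compounds shown here, this shows that the large step seen on the core of compound 2 cannot be assumed for the same exchange on the core of compound 3, but it does not show why the two cores differ, and with only two pairs at hand it gives no rule for how the change would behave on any further core.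

The compounds shown leave open whether a hydroxy group, a fluorine atom or a longer ether such as ethoxy in that place would follow the methoxy group or the hydrogen on either core. They also leave open how the two cores would compare at lower concentrations, since a read-out at one concentration is not a potency.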